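Aryl substitution on the shared core: compound 3 to compound 4

A few compounds are considered here, and "the series" means these few. Any claim that something is new, unique, unknown or untested is made for them only; others in the source may bear on it.

Measured so far:
compound 1 `CNC(=O)c1cc(Oc2ccc(NC(=O)c3cc4cccnc4n(-c4ccccc4F)c3=O)cc2)ccn1` gives 260 nM
compound 2 `CNC(=O)c1cc(Oc2ccc(NC(=O)c3cc4cccnc4n(-c4ccc(F)cc4)c3=O)cc2)ccn1` gives 160 nM
compound 3 `CCNC(=O)c1cc(Oc2ccc(NC(=O)c3cc4cccnc4n(-c4ccc(F)cc4)c3=O)cc2)ccn1` gives 190 nM

In a functional assay on HT-29 cells (Homo sapiens) for antiproliferative activity, read by MTT assay, with a stated time of 72 h (a lower number here means a stronger inhibitor, a higher number a weaker inhibitor), compound 3 stands second highest of the three numbers, and both its neighbours lie within the scatter of it. Compound 4 `CCNC(=O)c1cc(Oc2ccc(NC(=O)c3cc4cccnc4n(-c4ccc(Br)cc4F)c3=O)cc2)ccn1` carries 4-bromo-2-fluorophenyl in place of 4-fluorophenyl on an aromatic nitrogen. Going by the values given here, the only step that bears on the aryl group on the aromatic nitrogen is a 1.6-fold lower number from compound 1 to compound 2 (0.21 log units; within the scatter), which stayed within the scatter; a 1.2-fold higher number from compound 2 to compound 3 (0.07 log units; within the scatter) concerns the chain on the amide-type nitrogen and was also within the scatter. Bromine on this ring has no precedent in the series, so no step beyond the scatter is expected in this assay; the expected step is a 1.1-fold higher number from compound 3 to compound 4 (0.02 log units; within the scatter). Compound 4 is therefore estimated at 200 nM, with a range from 80 nM to 500 nM.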

Compound 4, half-maximal inhibitory concentration: 2070 nM
The estimate for compound 4 lay 10-fold (1.01 log units) below the measured number; measured number above the stated range.
By their numbers in this assay, from the lowest: compounds 2, 3 and 1 (each within the scatter of the next); then compound 4.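

In this assay the aryl group on the aromatic nitrogen can move the number beyond the scatter: the change gives an 11-fold higher number from compound 3 to compound 4 (1.04 log units; beyond the scatter) and thus departs from the fluorine exchange, a 1.6-fold lower number from compound 1 to compound 2 (0.21 log units; within the scatter). Hydrogen-bond donors, acceptors and net charge stay the same between 4-fluorophenyl and 4-bromo-2-fluorophenyl, and the single step cannot separate the contribution of the bromine from that of the fluorine. Nothing available explains the size of this step.
Going by these compounds, it remains open whether 4-bromophenyl alone would give such a step. On these data alone, how an unsubstituted phenyl or a 4-methoxyphenyl would read at this position also remains open.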